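A few compounds are considered here, and "the series" means these few. Any claim that something is new, unique, unknown or untested is made for them only; others in the source may bear on it.

Of the compounds shown here, three have been measured in a functional assay on SK-MEL-5 cells (Homo sapiens) for cytotoxicity, read by sulforhodamine B assay, with a stated time of 48 h; a lower number here means a stronger inhibitor of growth, a higher number a weaker inhibitor of growth. Compound 1 `Nc1nc(Cl)c2ncn(Cc3ccc(CCl)cc3)c2n1` gives 15500 nM, compound 2 `ClCc1cccc(Cn2cnc3c(Cl)nc(Cl)nc32)c1` gives 1580 nM, and compound 3 `ClCc1ccc(Cn2cnc3c(Cl)nc(Cl)nc32)cc1` gives 6460 nM. Compound 3 and compound 1 differ by one change, (amino in place of chloro on an aromatic carbon), and that change made a 2.4-fold higher number from compound 3 to compound 1 (0.38 log units; beyond the scatter). Compound 2 and compound 3 hold the same atoms joined differently, and the difference between their two cores is not broken down here. Compound 4 `Nc1nc(Cl)c2ncn(Cc3cccc(CCl)c3)c2n1` has not yet been measured. For the measured compounds named here, it differs from compound 2 by amino in place of chloro on an aromatic carbon, the same change in the same place as the one seen between compound 3 and compound 1. Resting on that earlier step, a matching move is expected in this assay, a 2.4-fold higher number from compound 2 to compound 4 (0.38 log units; beyond the scatter). Compound 4 is therefore estimated to give 3800 nM in this assay.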

Compound 4, concentration for 50% growth inhibition: 11000 nM
Compound 4: the middle estimate sits 2.9-fold (0.46 log units) below what was measured, and the stated range ends below it.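

In this assay, amino in place of chloro on an aromatic carbon gave a 7.0-fold higher number from compound 2 to compound 4 (0.84 log units; beyond the scatter). The direction of the step held on both cores, but its size did not carry over: the same change on two cores in this assay, a 2.4-fold higher number (0.38 log units; beyond the scatter) from compound 3 to compound 1 and a 7.0-fold higher number (0.84 log units; beyond the scatter) from compound 2 to compound 4, 2.9-fold (0.46 log units) apart, beyond the scatter of two such steps The change therefore cannot be moved between these cores as a fixed step, and two pairs show neither why the sizes differ nor whether the direction would hold on any other core.

The compounds shown leave open whether another group in that place, such as methylamino or methoxy, would behave alike on both cores. They also leave open what a methyl or hydroxymethyl group in place of the chloromethyl group would do.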